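This account rests on a few compounds, and the source may have more. Where it says the series, first, only, none or still open, it means among the compounds named here.

Compound 1 `O=C(Nc1cccc(OCc2cn(-c3ccccc3)nn2)c1)Nc1ccc(Cl)c(C(F)(F)F)c1` and compound 2 `Cc1ccc(-n2cc(COc3cccc(NC(=O)Nc4ccc(Cl)c(C(F)(F)F)c4)c3)nn2)cc1` share one core and differ in a single spot. In a functional assay on HepG2 cells (Homo sapiens) for inhibition, read by MTT assay, with a stated time of 72 h (a higher number here means a weaker inhibitor, a lower number a stronger inhibitor), compound 1 gives 1780 nM, and in this assay compound 2 gives 5430 nM. The step of a 3.1-fold higher number from compound 1 to compound 2 (0.48 log units; beyond the scatter) is the only one measured here. Compound 2 therefore stands with the highest number of the two, with compound 1 as its nearest neighbour.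

Compound 3 `CCc1cccc(-n2cc(COc3cccc(NC(=O)Nc4ccc(Cl)c(C(F)(F)F)c4)c3)nn2)c1` is not yet measured. Relative to compound 2 the change is 3-ethylphenyl in place of 4-methylphenyl on an aromatic nitrogen. Within the data shown here, only the step from compound 1 to compound 2 bears on this change, since it is the one case in which a group on that ring was altered, and it was modest. Among the measured compounds shown here, the new change is of a similar kind, a small alkyl group on the same ring, though larger and placed differently, so no measured step tells its direction directly. The expected step of a 1.1-fold lower number from compound 2 to compound 3 (0.04 log units; within the scatter) is therefore small, within or near the scatter. Compound 3 is estimated in this assay at 5000 nM, with a range from 2000 nM to 13000 nM.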

Compound 3, half-maximal inhibitory concentration: 37900 nM
Compound 3: the middle estimate sits 7.6-fold (0.88 log units) below what was measured; the whole stated range lies below it.
By their numbers in this assay, from the lowest: compound 1; then compound 2; then compound 3.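

The phenyl ring on the aromatic nitrogen proves more sensitive to its alkyl group than the earlier pair could show: replacing 4-methylphenyl with 3-ethylphenyl gives a 7.0-fold higher number from compound 2 to compound 3 (0.84 log units; beyond the scatter) in this assay, a step well beyond the scatter. Set against the ring without an alkyl group, ethyl in place of hydrogen gives a 21-fold higher number from compound 1 to compound 3 (1.33 log units; beyond the scatter), a large step, whereas the methyl change gave the modest 3.1-fold higher number from compound 1 to compound 2 (0.48 log units; beyond the scatter), so both alkyl-bearing compounds read weaker than compound 1, and neither goes against that direction. No measurement offered here accounts for the loss of activity on moving to the 3-ethylphenyl group.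

The size of the alkyl group and its place on the ring change together in the step to compound 3, so the compounds shown leave open which of the two carries the difference. They also leave open how an amine, a carboxylic acid or a longer chain on this ring would read in this assay, and whether the trend with alkyl groups would continue with a propyl group.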